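Sulfonyl aryl exchange at the limit of the assay

This account rests on a few compounds, and the source may have more. Where it says the series, first, only, none or still open, it means among the compounds named here.

Compound 1 `CC1=NN(C(=O)CBr)C(c2ccccc2O)C1`: 3650 nM
Compound 2 `COc1ccc(C(=O)N2N=C(C)CC2c2ccccc2O)cc1`: 38500 nM
Compound 3 `CC1=NN(S(=O)(=O)c2ccccc2C)C(c2cc(Br)ccc2O)C1`: > 60000 nM (a limit)

All three values come from a functional assay on MGC-803 cells (Homo sapiens) for antiproliferative activity, read by MTT assay, with a stated time of 48 h; on this read-out lower numbers stand for an effect already at smaller amounts and higher numbers for an effect only at larger amounts of compound. Compound 3 stands at the limit of > 60000 nM in this assay, at which 1 of the 3 values shown sits; this is a limit and not a number.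

Compound 4 `CC1=NN(S(=O)(=O)c2ccc(Cl)cc2Cl)C(c2cc(Br)ccc2O)C1` carries 2,4-dichlorophenyl in place of 2-methylphenyl on a sulfonyl sulfur. Among the compounds with values here, no measured step covers this exchange, so the expectation is loose, and compound 4 may also end at the limit. It leans on compound 2 (38500 nM), whose value is also high. The estimated step of an at least 2.0-fold lower number from compound 3 to compound 4 (0.30 log units; that floor lies within the scatter) is moderate and points towards lower numbers in this assay. For compound 4 the expected value is 30000 nM, within an estimated range from 7000 nM to 60000 nM.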

Compound 4, half-maximal effective concentration: 37900 nM
Beside the measured number, compound 4's estimate is 1.3-fold (0.10 log units) below it; low and high end bracket the measured number.
By their numbers in this assay, from the lowest: compound 1; then compounds 4 and 2 (each within the scatter of the next). At a limit, above all of these: compound 3.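

With 2,4-dichlorophenyl on the sulfonyl sulfur, compound 4 gives a readable number in this assay: 37900 nM. As far as these compounds go, the exchange amounts to an at least 1.5-fold lower number from compound 3 to compound 4 (0.19 log units; that floor lies within the scatter), and its true size stays unknown. Compound 3 is a limit and not a number, so only a floor can be read: the limit of > 60000 nM in this assay, at which 1 of the 4 values shown sits.

Open, from the compounds shown here alone, is whether either chlorine alone carries this step. Also open, going by these compounds, is how an aminophenyl or a carboxyphenyl group in place of 2,4-dichlorophenyl on a sulfonyl sulfur would read in this assay.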